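Propargyl in place of 4-fluorophenyl: notes on the series

The source may hold more compounds than are shown below. What is called first, only, known or untested is meant among the compounds shown, and "the series" means these compounds.

In a functional assay on PC-3 cells (Homo sapiens) for inhibition, read by sulforhodamine B assay, with a stated time of 48 h, tested at 50 uM (on this read-out higher numbers stand for more inhibition of growth at the one concentration tested and lower numbers for less inhibition of growth), compound 1 `COc1ccc([C@@H]2C/C(=N/O)c3cc(CC=C(C)C)c(OC)cc3O2)cc1` gives 45% and compound 2 `COc1cc2c(cc1CC=C(C)C)C(=O)C[C@@H](c1ccc(Oc3ccc(F)cc3)cc1)O2` gives 19%. Compound 2 therefore holds the lower of the two numbers, and its gap to compound 1 lies beyond the scatter.

Compound 3 `C#CCOc1ccc([C@@H]2CC(=O)c3cc(CC=C(C)C)c(OC)cc3O2)cc1` differs from compound 2 by one exchange, propargyl in place of 4-fluorophenyl on an oxygen on an aromatic ring. For the measured compounds named here, no measured step covers this exchange, so the expectation rests only on compound 2 at 19% and compound 1 at 45%. A moderate rise in this assay is expected, although a change within the scatter remains possible. The expected change is a number 14 percentage points higher from compound 2 to compound 3 (beyond the scatter). For compound 3 the estimated value is 33%, with an expected range of 14% to 55%.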

Compound 3, percent growth inhibition at one concentration: 52%
Estimate against measurement, compound 3: 19 percentage points below; the measured number falls inside the stated range.
By their numbers in this assay, from the lowest: compound 2; then compounds 1 and 3 (each within the scatter of the next).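

For the compounds shown here, the exchange of 4-fluorophenyl for propargyl on an oxygen on an aromatic ring gives the first direct reading at this position: in this assay it produces a number 33 percentage points higher from compound 2 to compound 3 (beyond the scatter) in the series. The aromatic ring at this place is therefore not needed for growth inhibition at the one concentration tested, since propargyl, with no ring and fewer heavy atoms, gives the higher number of this pair. Nothing on hand bears on the reason for this step, and it cannot be assigned to the loss of 4-fluorophenyl or to the entry of the triple bond.

From the compounds shown here alone, whether a propyl chain, which lacks the triple bond, would hold the gain remains open. Also open, going by these compounds, is whether a longer chain such as 2-butynyl or a polar group such as an aminoethyl chain would be accepted on the same oxygen.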